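The source may hold more compounds than are shown below. What is called first, only, known or untested is meant among the compounds shown, and "the series" means these compounds.

Three compounds have been examined in an assay on cells for agonist activity at Bombesin receptor subtype-3 (Mus musculus), read by HTRF and inositol phosphate accumulation, with a stated time of 1 h; on this read-out lower numbers stand for an effect already at smaller amounts and higher numbers for an effect only at larger amounts of compound. Compound 1, `COC(=O)c1ccccc1-c1ccc(CCc2ncc(CC(C)(C)C)n2CC(=O)O)cc1`, gives 694 nM. Compound 2, `COC(=O)c1c(F)cccc1-c1ccc(CCc2ncc(CC(C)(C)C)n2CCC(=O)O)cc1`, gives 3 nM and stands lowest of the three. Compound 3, `CC(C)(C)Cc1cnc(CCc2ccc(-c3ccccc3C(=O)O)cc2)n1CC(=O)O`, gives 1270 nM.

Compound 1 and compound 3 differ in one place only, and the change is hydrogen in place of methyl on an oxygen next to a carbonyl group. The step from this change was a 1.8-fold higher number from compound 1 to compound 3 (0.26 log units; within the scatter), so the two numbers sit within the usual spread of repeated measurements and no direction can be read from them.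

Compound 2 differs from compound 1 in more than one place, and the difference between the two cores is not broken down here. Its own number lies far from those of compound 1 and compound 3, and both of those gaps are beyond the scatter.

Compound 4, `CC(C)(C)Cc1cnc(CCc2ccc(-c3cccc(F)c3C(=O)O)cc2)n1CCC(=O)O`, has not yet been measured in this assay. It stands to compound 2 as compound 3 stands to compound 1: the change is hydrogen in place of methyl on an oxygen next to a carbonyl group. The place of this change is the same, word for word, as in the pair of compound 1 and compound 3, so it is the same change made on a different core.

Among the compounds with values here, the only guide is the earlier pair, where the step was a 1.8-fold higher number from compound 1 to compound 3 (0.26 log units; within the scatter), which did not leave the scatter. Compound 4 is therefore expected to remain close to compound 2, with an estimated step of a 1.7-fold higher number from compound 2 to compound 4 (0.22 log units; within the scatter), because compound 2 gives 3 nM and the earlier step was small. For compound 4 the estimated value in this assay is 5 nM, with a likely range from 2 nM to 15 nM.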

Compound 4, half-maximal effective concentration: 61 nM
Compound 4: middle estimate off by 12-fold (1.09 log units), on the low side; measured number above the stated range.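

Turning the methoxycarbonyl group of compound 2 into the carboxy group of compound 4 gave a 20-fold higher number from compound 2 to compound 4 (1.31 log units; beyond the scatter) in this assay, so on this core the methyl on that oxygen makes a large difference to the number. The same change did not have the same size on the two cores, so the small step seen on the first core could not be carried over to the second: the same change on two cores in this assay, a 1.8-fold higher number (0.26 log units; within the scatter) from compound 1 to compound 3 and a 20-fold higher number (1.31 log units; beyond the scatter) from compound 2 to compound 4, 11-fold (1.05 log units) apart, beyond the scatter of two such steps. Within the data shown here, this shows that, in this series, the size of this step depends on the core it is made on, but it rests on only two pairs and does not show which of the several differences between the cores is responsible, nor does it give a rule for other cores.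

The compounds shown leave open which single difference between the two cores accounts for the gap between the steps, as no compound here separates those differences one at a time. They also leave open how an ethyl group on that same oxygen, or a primary amide in place of the methoxycarbonyl group, would read on either core.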